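The source may hold more compounds than are shown below. What is called first, only, known or untested is meant among the compounds shown, and "the series" means these compounds.

Compound 1 `CCCCCCCC/C=C\CCCCCCCCCCCC(=O)O[C@H]1[C@H](O)[C@H](n2ccc(N)nc2=O)O[C@@H]1CO` carries a long unsaturated ester chain on a shared core. Among the measured compounds shown here, in a functional assay on HeLa cells (Homo sapiens) for cytotoxicity, read by cell counting, with a stated time of 48 h (a lower number here means that less compound is needed, a higher number that more compound is needed for the effect), compound 1 gives 0.16 ug/mL, the highest of the two numbers so far, though within the scatter of compound 2 `CC(=O)O[C@H]1[C@H](O)[C@H](n2ccc(N)nc2=O)O[C@@H]1CO`, which in this assay gives 0.14 ug/mL. Compound 3 `CCCCCCCCCCCCCCCCCCCCCC(=O)O[C@H]1[C@H](O)[C@H](n2ccc(N)nc2=O)O[C@@H]1CO` differs from compound 1 in one place: decyl in place of dec-1-en-1-yl on a saturated chain carbon, ten or more bonds along the chain from a carbonyl carbon. For the measured compounds named here, no measured step of this kind is available, so the step from compound 1 to compound 3 is expected to stay within the scatter, with an estimated 1.1-fold higher number from compound 1 to compound 3 (0.05 log units; within the scatter). Compound 3 is therefore estimated at 0.18 ug/mL, within 0.08 ug/mL to 0.4 ug/mL.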

Compound 3, concentration for half-maximal effect: 1.1 ug/mL
The estimate for compound 3 lay 6.1-fold (0.79 log units) below the measured number, outside the stated range (above it).
By their numbers in this assay, from the lowest: compounds 2 and 1 (each within the scatter of the next); then compound 3.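

Saturating the single double bond in the chain, with the number of heavy atoms in the swapped group unchanged, gives a 6.9-fold higher number from compound 1 to compound 3 (0.84 log units; beyond the scatter), so more compound is needed for the effect. The result shows that a small change on a saturated chain carbon can still shift this number beyond the scatter. Nothing measured here explains this step.

Going by these compounds, whether a trans double bond or a longer chain would behave like dec-1-en-1-yl or like decyl remains open.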